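One Swap in Two Settings: Methyl to Methylsulfanyl

This account rests on a few compounds, and the source may have more. Where it says the series, first, only, none or still open, it means among the compounds named here.

The set holds three measured compounds and one still awaiting measurement. Compound 1 `C[C@H]1O[C@@H](n2cnc3c(N)nc(C#N)nc32)[C@H](O)[C@@H]1O` gives 177000 nM in an ADME assay on L6 cells (Rattus norvegicus) for cytotoxicity; on this read-out higher numbers stand for weaker inhibition and lower numbers for stronger inhibition. Compound 2 `CS[C@H]1O[C@@H](n2cnc3c(N)nc(C#N)nc32)[C@H](O)[C@@H]1O` gives 153000 nM in this assay; the change from compound 1 is methylsulfanyl in place of methyl on a saturated ring carbon, and the step is a 1.2-fold lower number from compound 1 to compound 2 (0.06 log units; within the scatter). Compound 3 `CNc1nc(C#N)nc2c1ncn2[C@@H]1O[C@H](C)[C@@H](O)[C@H]1O` differs from compound 1 in its core by methyl in place of hydrogen on a nitrogen on an aromatic ring; in this assay compound 3 gives 85000 nM, a step of a 2.1-fold lower number from compound 1 to compound 3 (0.32 log units; beyond the scatter). Compound 4 `CNc1nc(C#N)nc2c1ncn2[C@@H]1O[C@H](SC)[C@@H](O)[C@H]1O` carries, on the core of compound 3, the change that turned compound 1 into compound 2: methylsulfanyl in place of methyl on a saturated ring carbon. The surroundings of the place are described in identical words for the two pairs, so this is the same change, not merely one of the same kind, and it occurs twice among the compounds shown. Because a 1.2-fold lower number from compound 1 to compound 2 (0.06 log units; within the scatter) stayed within the scatter, the expected step is a 1.1-fold lower number from compound 3 to compound 4 (0.05 log units; within the scatter). The estimate for compound 4 in this assay is 75000 nM, with a likely range from 40000 nM to 150000 nM.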

Compound 4, half-maximal inhibitory concentration: 24000 nM
For compound 4 the middle estimate is 3.1-fold (0.49 log units) above the measured one; measured number outside the range, below it.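

In this assay, methylsulfanyl in place of methyl brings a 3.5-fold lower number from compound 3 to compound 4 (0.55 log units; beyond the scatter), so this change does not carry over with the same size from one core to the other: the same change on two cores in this assay, a 1.2-fold lower number (0.06 log units; within the scatter) from compound 1 to compound 2 and a 3.5-fold lower number (0.55 log units; beyond the scatter) from compound 3 to compound 4, 3.1-fold (0.49 log units) apart, beyond the scatter of two such steps

Seen from the other side, methyl in place of hydrogen on the nitrogen brings a 6.4-fold lower number from compound 2 to compound 4 (0.80 log units; beyond the scatter), and this step also differs between the two cores: the same change on two cores in this assay, a 2.1-fold lower number (0.32 log units; beyond the scatter) from compound 1 to compound 3 and a 6.4-fold lower number (0.80 log units; beyond the scatter) from compound 2 to compound 4, 3.1-fold (0.49 log units) apart, beyond the scatter of two such steps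

Both gaps come from the same four compounds and so form a single observation: the size of the methylsulfanyl step depends on the core in this small set, but the data show neither why this happens nor whether it would hold on any other core.

The compounds shown leave open whether a longer chain on that nitrogen, such as ethyl, would widen or narrow the gap between the two steps. They also leave open whether ethylsulfanyl or an amine on the saturated ring carbon would follow methylsulfanyl in this assay.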